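The compounds below may be only part of what the source reports. "The series", "measured", "known", "first", "only" and "open" are said of these compounds alone.

Compound 1 `COC(=O)N[C@H](C(=O)NN(CC[C@@](O)(Cc1ccccc1)C(=O)N[C@H]1c2ccccc2C[C@H]1O)Cc1ccc(-c2ccccc2)cc1)C(C)(C)C`: in an ADME assay on MT4 cells (Homo sapiens) for cytotoxicity, read by XTT assay, with a stated time of 5 days (a lower number here means that less compound is tolerated, a higher number that more compound is tolerated), compound 1 gives > 10000 nM, which is a limit of the assay and not a number.
Compound 2 `COC(=O)N[C@H](C(=O)NN(CC[C@@](O)(Cc1ccccc1)C(=O)N[C@H]1c2ccccc2C[C@H]1O)Cc1ccc(-c2ccccn2)cc1)C(C)(C)C`: in this assay compound 2 gives > 10000 nM, again a limit rather than a number.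
Compound 3 `COC(=O)N[C@H](C(=O)NN(CC[C@@](O)(Cc1ccccc1)C(=O)N[C@H]1c2ccccc2C[C@H]1O)Cc1ccc(-c2c(C)noc2C)cc1)C(C)(C)C`: in this assay compound 3 gives > 10000 nM, also a limit.

Compound 2 therefore stands at the edge of what this assay can report, and it is not alone there: the limit of > 10000 nM in this assay, at which 3 of the 3 values shown sit. The change examined here takes compound 2 to compound 4 `COC(=O)N[C@H](C(=O)NN(CC[C@@](O)(Cc1ccccc1)C(=O)N[C@H]1c2ccccc2C[C@H]1O)Cc1ccc(-c2cnn(C)c2)cc1)C(C)(C)C` through (1-methyl-1H-pyrazol-4-yl in place of pyridin-2-yl on an aromatic carbon).

Going by the values given here, two measured steps touch the same position. The step that the two limits leave unreadable from compound 1 to compound 2 and the step that the two limits leave unreadable from compound 2 to compound 3 both run between limits, so neither shows a readable size or direction. Among the compounds with values here, they say only that swapping one ring for another at this position has, so far, never brought the cytotoxicity down into the measurable range.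

For compound 4 the expectation is the same: a step that the limit leaves unreadable from compound 2 to compound 4, that is, none beyond the scatter. Compound 4 is estimated at 15000 nM in this assay, in a range from 8000 nM to 30000 nM, with the result most likely reported again as a limit.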

Compound 4, half-maximal cytotoxic concentration: > 10000 nM
Compound 4 gave a limit, no number; the forecaster's own chance of this, stated with the estimate: 85%; the middle value is on the limit's open side.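

In this assay, going by these compounds alone, compound 4 gives > 10000 nM, a limit and not a number, so no step linking it to compound 1, compound 2 or compound 3 can be read. All four compounds sit at the same edge: the limit of > 10000 nM in this assay, at which 4 of the 4 values shown sit.

On these data alone, what stays open is how much compound each tolerated cell culture would really take, and whether any ring at this position would give a measurable cytotoxicity.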